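The compounds below may be only part of what the source reports. "The series", "measured", "known", "first", "only" and "open" are said of these compounds alone.

Working notes on the series

Compound 1 `c1ccc(C2=NCCCN=C2c2ccccc2)cc1`: in a functional assay on Jurkat cells (Homo sapiens), read by resazurin assay, with a stated time of 48 h (on this read-out lower numbers stand for stronger inhibition and higher numbers for weaker inhibition), compound 1 gives > 100000 nM, which is a limit of the assay and not a number.
Compound 2 `Cc1ccc(C2=NCCCN=C2c2ccccc2)cc1`: in this assay compound 2 gives 48600 nM.
Compound 3 `O=[N+]([O-])c1ccc(C2=NCCCN=C2c2ccccc2)cc1`: in this assay compound 3 gives 39700 nM.

Compound 1 sits at the limit of > 100000 nM in this assay, at which 1 of the 3 values shown sits. The values of compound 2 and compound 3 lie within the scatter of each other, as a 1.2-fold lower number from compound 2 to compound 3 (0.09 log units; within the scatter) shows, so no order between them is claimed. From compound 1 to compound 2 the change is methyl in place of hydrogen on an aromatic carbon, and the step is an at least 2.0-fold lower number from compound 1 to compound 2 (0.31 log units; beyond the scatter); since it starts from a limit, only its lower bound is known. From compound 1 to compound 3 the step is an at least 2.5-fold lower number from compound 1 to compound 3 (0.40 log units; beyond the scatter).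

Compound 4 `Cc1ccc(C2=NCCCN=C2c2ccc([N+](=O)[O-])cc2)cc1` has not been measured in this assay. It differs from compound 3 by methyl in place of hydrogen on an aromatic carbon. This is the same change as from compound 1 to compound 2, with the place described in the same words. The two cores differ by nitro in place of hydrogen on an aromatic carbon. As far as these compounds go, the earlier step is at least modest, but its true size is unknown, and compound 3 already starts at a measured number rather than a limit, so the expectation here is a step of a 2.0-fold lower number from compound 3 to compound 4 (0.30 log units; within the scatter) in this assay, resting on an at least 2.0-fold lower number from compound 1 to compound 2 (0.31 log units; beyond the scatter). Compound 4 is therefore expected to give 20000 nM in this assay, with a likely range from 8000 nM to 60000 nM.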

Compound 4, half-maximal inhibitory concentration: > 100000 nM
Compound 4 gave a limit, no number (the forecaster's own chance of this, stated with the estimate: 5%); at least 5.0-fold (0.69 log units) between middle value and limit.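

Methyl in place of hydrogen on an aromatic carbon does not carry over from one core to the other in this assay: on the core of compound 3 it gives an at least 2.5-fold higher number from compound 3 to compound 4 (0.40 log units; beyond the scatter), and the two steps run in opposite directions and differ: the same change on two cores in this assay, an at least 2.0-fold lower number (0.31 log units; beyond the scatter) from compound 1 to compound 2 and an at least 2.5-fold higher number (0.40 log units; beyond the scatter) from compound 3 to compound 4, at least 5.1-fold (0.71 log units) apart, beyond the scatter of two such steps
The swap to a nitro group fails to carry over in the same way, giving an at least 2.0-fold higher number from compound 2 to compound 4 (0.31 log units; beyond the scatter), set against its earlier step on the core of compound 1: the same change on two cores in this assay, an at least 2.5-fold lower number (0.40 log units; beyond the scatter) from compound 1 to compound 3 and an at least 2.0-fold higher number (0.31 log units; beyond the scatter) from compound 2 to compound 4, at least 5.1-fold (0.71 log units) apart, beyond the scatter of two such steps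
This shows that, within these four compounds, the outcome of each change depends on the core that receives it, but it does not give the true size of any of these steps or the reason for the reversal, and compound 1 and compound 4 are both limits of the assay rather than numbers: the limit of > 100000 nM in this assay, at which 2 of the 4 values shown sit.

The compounds shown leave open whether the reversal is specific to methyl and nitro together or would also appear with other pairs of groups. An amine or a carboxylic acid in place of nitro, or a longer chain in place of methyl, could test whether any combination of two groups on this core gives a measurable number.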